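A few compounds are considered here, and "the series" means these few. Any claim that something is new, unique, unknown or untested is made for them only; others in the source may bear on it.

Measured in a functional assay on SK-BR-3 cells (Homo sapiens) for antiproliferative activity, read by MTT assay, with a stated time of 72 h; a higher number here means a weaker inhibitor, a lower number a stronger inhibitor:
Compound 1 `C/C=C1/[C@H](O[C@@H]2O[C@H](CO)[C@@H](O)[C@H](O)[C@H]2O)OC=C(C(=O)OC)[C@H]1CC(=O)NCCC` gives > 20000 nM, a limit of the assay.
Compound 2 `C/C=C1/[C@H](O[C@@H]2O[C@H](COC(C)=O)[C@@H](OC(C)=O)[C@H](OC(C)=O)[C@H]2OC(C)=O)OC=C(C(=O)O)[C@H]1CC(=O)OCCCCCCCCCCCCCCC` gives > 20000 nM, also a limit.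
Compound 3 `C/C=C1/[C@H](O[C@@H]2O[C@H](COC(C)=O)[C@@H](OC(C)=O)[C@H](OC(C)=O)[C@H]2OC(C)=O)OC=C(C(=O)OC)[C@H]1CC(=O)SCCc1ccccc1` gives > 15000 nM, again a limit.

Compound 1 therefore stands at no measured number in this assay, only at a limit; the same holds for the other two, one at the limit of > 15000 nM in this assay, at which 1 of the 3 values shown sits, and two at the limit of > 20000 nM in this assay, at which 2 of the 3 values shown sit. Compound 4 `C/C=C1/[C@H](O[C@@H]2O[C@H](CO)[C@@H](O)[C@H](O)[C@H]2O)OC=C(C(=O)OC)[C@H]1CC(=O)OCc1ccc2c(c1)OCCO2` is not yet measured. It differs from compound 1 by a group of 12 heavy atoms (9 carbon, 3 oxygen; one six-membered non-aromatic ring with 2 hetero atoms, one six-membered aromatic ring of carbon only) in place of a group of 4 heavy atoms (3 carbon, 1 nitrogen; no ring), on a carbonyl carbon. Among the compounds with values here, no step between measured compounds is available, and with compound 1 at a limit no direction can be read. Compound 4 is expected to stay at a limit, so the step of a number no higher from compound 1 to compound 4 (the limit leaves the size open) is expected to be none beyond the scatter. The value of compound 4 is estimated at 20000 nM, between 6000 nM and 60000 nM.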

Compound 4, half-maximal inhibitory concentration: > 15000 nM
Compound 4: only a limit was reported (the forecaster's own chance of this, stated with the estimate: 80%); the middle value does not contradict the limit.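

Compound 1 and compound 4 both stand only at limits of the assay, so the step between them cannot be read. The compounds shown leave open whether any group on that carbonyl carbon gives a measured number in this assay.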